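Butyl to isopentyl on compound 3

This account rests on a few compounds, and the source may have more. Where it says the series, first, only, none or still open, it means among the compounds named here.

Measured in a functional assay on EOL1 cells (Homo sapiens) for inhibition, read by fluorescence, with a stated time of 72 h; on this read-out higher numbers stand for weaker inhibition of growth and lower numbers for stronger inhibition of growth:
Compound 1 `COc1ccc(Nc2nc(N[C@H]3CC[C@H](N)CC3)nc3c2ncn3CCC(C)C)c(OC)c1`: 630 nM
Compound 2 `CC(C)CCn1cnc2c(Nc3ccc(Cl)cc3)nc(N[C@H]3CC[C@H](N)CC3)nc21`: 90 nM
Compound 3 `CCCCn1cnc2c(NCc3cccc(Cl)c3)nc(N[C@H]3CC[C@H](N)CC3)nc21`: 350 nM

Compound 3 lies within the scatter of compound 1, while compound 2 has the lower number, beyond the scatter. Compound 4 `CC(C)CCn1cnc2c(NCc3cccc(Cl)c3)nc(N[C@H]3CC[C@H](N)CC3)nc21` differs from compound 3 by methyl in place of hydrogen on a saturated chain carbon bound to two saturated chain carbons, or butyl to isopentyl. Going by the values given here, the only measured step, a 7.0-fold lower number from compound 1 to compound 2 (0.85 log units; beyond the scatter), concerns the group on a nitrogen on an aromatic ring and does not touch the chain, so it bears on this change only weakly. Among the compounds with values here, no measured step covers the chain, so no shift beyond the scatter is expected in this assay, and no direction is favoured. The expected step is a 1.2-fold lower number from compound 3 to compound 4 (0.07 log units; within the scatter). For compound 4 the estimate is 300 nM, with an expected range of 120 nM to 700 nM.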

Compound 4, concentration for 50% growth inhibition: 1330 nM
Beside the measured number, compound 4's estimate is 4.4-fold (0.65 log units) below it, and the stated range ends below it.
By their numbers in this assay, from the lowest: compound 2; then compounds 3 and 1 (each within the scatter of the next); then compound 4.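

In this assay, the chain on the shared core proves sensitive: butyl to isopentyl, with 3-chlorobenzyl held, gives a higher number (a 3.8-fold higher number from compound 3 to compound 4 (0.58 log units; beyond the scatter)). With isopentyl held, 3-chlorobenzyl on the nitrogen compares unfavourably with 4-chlorophenyl (a 15-fold higher number from compound 2 to compound 4 (1.17 log units; beyond the scatter)) and with 2,4-dimethoxyphenyl (a 2.1-fold higher number from compound 1 to compound 4 (0.32 log units; beyond the scatter)). Nothing available explains why the added methyl raises the number.

Open, as far as these compounds go, is whether butyl would also give the lower number with 4-chlorophenyl on that nitrogen. Also open, from the compounds shown here alone, is how a longer chain, or a chain ending in an amine, would behave.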